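This account rests on a few compounds, and the source may have more. Where it says the series, first, only, none or still open, it means among the compounds named here.

Series notes. In an assay on FRT cells with Cystic fibrosis transmembrane conductance regulator variant F508del (Homo sapiens) as the target, read by fluorescence, with a stated time of 25 min (on this read-out higher numbers stand for larger maximal responses and lower numbers for smaller maximal responses), compound 1 `CN(C)CCN1CCN(c2nc(-c3ccccn3)nc3c2CN(Cc2ccccc2)CC3)CC1` gives 41.3%, while compound 2 `CN(C)CCN1CCN(c2nc(-c3ccccn3)nc3c2CN(Cc2ccc(F)cc2)CC3)CC1` is recorded in this assay as "not active" (no number reported). Compound 3 `CC(=O)NCCNc1nc(-c2ccccn2)nc2c1CN(Cc1ccc(F)cc1)CC2` gives 73.8% in this assay, the highest of the two numbers available; the nearest, compound 1, lies lower by a gap beyond the scatter, and compound 2 contributes no number. Compound 4 `Fc1ccc(CN2CCc3nc(-c4ccccn4)nc(NCCN4CCCC4)c3C2)cc1` has not yet been measured in this assay. It differs from compound 3 by pyrrolidin-1-yl in place of acetamido on a saturated chain carbon, two bonds along the chain from a nitrogen on an aromatic ring. Going by the values given here, no measured pair shows this exact change. Compound 1 gives 41.3% and compound 2 gives "not active" (no number reported), both with a chain of a different kind than compound 3. A downward step, beyond the scatter, is expected: a number 28.8 percentage points lower from compound 3 to compound 4 (beyond the scatter). Compound 4 is therefore estimated at 45%, with a range from 15% to 75%.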

Compound 4, largest response reached (Emax), in percent of the reference or control that the assay uses: 40%
Compound 4: the middle estimate sits 5 percentage points above what was measured; the range from low to high includes it.
By their numbers in this assay, from the lowest: compounds 4 and 1 (each within the scatter of the next); then compound 3.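

In this assay, going by these compounds alone, pyrrolidin-1-yl in place of acetamido on a saturated chain carbon, two bonds along the chain from a nitrogen on an aromatic ring, brings a number 33.8 percentage points lower from compound 3 to compound 4 (beyond the scatter) as the first reading of a single change here. The response at this position therefore depends on the group at the chain end, yet it is not lost with this ring in place. Nothing on hand accounts for the step. Open, from the compounds shown here alone, is whether dimethylamino, a carboxylic acid or a longer chain at this place would give a response nearer that of the acetamido or further from it.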